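Ester ring size and thiophene attachment in one series

The source may hold more compounds than are shown below. What is called first, only, known or untested is meant among the compounds shown, and "the series" means these compounds.

Measured so far, in an assay on membranes from HEK293 cells for displacement of a labelled ligand from adenosine receptor A2b (Homo sapiens), read by scintillation counting, with a stated time of 30 min; on this read-out higher numbers stand for weaker inhibition and lower numbers for stronger inhibition:
compound 1 `CC1=C(C(=O)OCC2CC2)C(c2cccs2)NC(=O)N1` gives 1570 nM
compound 2 `CC1=C(C(=O)OCC2CCC2)C(c2cccs2)NC(=O)N1` gives 2840 nM
compound 3 `CC1=C(C(=O)OCC2CC2)C(c2ccsc2)NC(=O)N1` gives 724 nM

Compound 1 and compound 2 share a core and differ only in the ester: cyclobutyl in place of cyclopropyl on a saturated chain carbon bound to an oxygen next to a carbonyl group. The step is a 1.8-fold higher number from compound 1 to compound 2 (0.26 log units; within the scatter), so the two numbers are not separated by this assay.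

Compound 3 carries the other thiophene attachment. The two cores differ in one place: thiophen-3-yl in place of thiophen-2-yl on a saturated ring carbon. The step is a 2.2-fold lower number from compound 1 to compound 3 (0.34 log units; beyond the scatter), and compound 3 gives the lowest number of the three.

Compound 4 `CC1=C(C(=O)OCC2CCC2)C(c2ccsc2)NC(=O)N1` is not yet measured. It stands to compound 3 as compound 2 stands to compound 1: cyclobutyl in place of cyclopropyl on a saturated chain carbon bound to an oxygen next to a carbonyl group. The place of the change is described in the same words for both pairs, so this is the same change, made on the core of compound 3 instead of the core of compound 1.

Among the measured compounds shown here, the expectation for compound 4 rests on the single precedent, the step from compound 1 to compound 2 in this assay, which was a 1.8-fold higher number from compound 1 to compound 2 (0.26 log units; within the scatter). Carrying that over, the estimated step is a 1.8-fold higher number from compound 3 to compound 4 (0.25 log units; within the scatter), with a wide band because one precedent within the scatter fixes neither direction nor size. Compound 4 is estimated at 1300 nM, between 550 nM and 3000 nM.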

Compound 4, inhibition constant: 1040 nM
Estimate against measurement, compound 4: 1.3-fold (0.10 log units) above; low and high end bracket the measured number.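

In this assay, cyclobutyl in place of cyclopropyl leaves the two numbers unseparated on the second core as well (a 1.4-fold higher number from compound 3 to compound 4 (0.16 log units; within the scatter)), and the two ester steps agree: the same change on two cores in this assay, a 1.8-fold higher number (0.26 log units; within the scatter) from compound 1 to compound 2 and a 1.4-fold higher number (0.16 log units; within the scatter) from compound 3 to compound 4, 1.3-fold (0.10 log units) apart, within the scatter of two such steps. Thiophen-3-yl in place of thiophen-2-yl, now read with the cyclobutylmethyl ester (a 2.7-fold lower number from compound 2 to compound 4 (0.44 log units; beyond the scatter)), is the step that stands beyond the scatter on both cores, and its size carries over: the same change on two cores in this assay, a 2.2-fold lower number (0.34 log units; beyond the scatter) from compound 1 to compound 3 and a 2.7-fold lower number (0.44 log units; beyond the scatter) from compound 2 to compound 4, 1.3-fold (0.10 log units) apart, within the scatter of two such steps. Across these four compounds, the two changes therefore behave as independent of each other, but this rests on one pair of steps per change, the ester steps do not fix a direction for the ring-size change, and nothing here extends the agreement to other esters, other ring substituents or other cores.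

Still open, going by these compounds, is whether the gain with thiophen-3-yl holds with an ester of a different kind, such as a longer straight chain, a benzyl group or a carboxylic acid in place of the ester. Also open, on these data alone, is whether the ester change reads the same when the thiophene gives way to a phenyl or furan ring, and whether a larger ring such as cyclopentyl would finally separate from cyclopropyl on this read-out.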